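This account rests on a few compounds, and the source may have more. Where it says the series, first, only, none or still open, it means among the compounds named here.

In a functional assay on the whole organism (strain Kunming) with Mus musculus as the target, with a stated time of 0.5 h (a higher number here means that more compound is needed for the effect, a lower number that less compound is needed), compound 1 (`COc1cc(OC)c(OC)cc1/C=C/COC(=O)/C=C/c1ccc(OC)c(OC)c1`) gives 140 umol/kg while compound 2 (`COc1cc(OC)c(OC)cc1/C=C/COC(=O)/C=C/c1c(OC)ccc(OC)c1OC`) gives 120 umol/kg and compound 3 (`COc1cc(OC)c(OC)cc1/C=C/COC(=O)/C=C/c1cc(OC)c(OC)c(OC)c1`) gives 74.7 umol/kg so all three lie within the usual scatter of one another. Compound 4 (`COc1cc(OC)c(OC)cc1/C=C/COC(=O)/C=C/c1cccc(Br)c1`) differs from compound 1 by one swap (3-bromophenyl in place of 3,4-dimethoxyphenyl on a double-bonded chain carbon bound to a double-bonded chain carbon), with 3-bromophenyl in place of 3,4-dimethoxyphenyl. For the measured compounds named here, the only measured single change on that ring puts methoxy in place of hydrogen on an aromatic carbon (a 1.9-fold lower number from compound 1 to compound 3 (0.27 log units; within the scatter)), and no measured compound carries bromine, so this is weak guidance. No step beyond the scatter is therefore expected in this assay in either direction. The estimated step (a 1.3-fold lower number from compound 1 to compound 4 (0.12 log units; within the scatter)) is correspondingly small. For compound 4 the expected value is 105 umol/kg (estimated range 45 umol/kg to 250 umol/kg).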

Compound 4, dose for half-maximal effect: 175 umol/kg
Compound 4: middle estimate off by 1.7-fold (0.22 log units), on the low side, within the range that was stated.
By their numbers in this assay, from the lowest: compounds 3, 2, 1 and 4 (each within the scatter of the next, the first and the last beyond it).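

For the compounds shown here, the swap to 3-bromophenyl in place of 3,4-dimethoxyphenyl gives a 1.3-fold higher number from compound 1 to compound 4 (0.10 log units; within the scatter) in this assay and is the first change here that removes both methoxy groups. At this place, on a double-bonded chain carbon bound to a double-bonded chain carbon, the group can thus go from 2 hydrogen-bond acceptors to 0 and take on a bromine without a step beyond the scatter. Nothing measured here speaks to the reason for this result.

As far as these compounds go, whether an amine or a carboxylic acid on this ring would also stay within the scatter remains open, and so does what a plain phenyl would give.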